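Acetylation of the sulfonamide in a pyrazole series

This account rests on a few compounds, and the source may have more. Where it says the series, first, only, none or still open, it means among the compounds named here.

Measured so far:
compound 1 `COc1ccc(OC)c(-c2cc(-c3ccccc3)nn2-c2ccc(S(=O)(=O)NC(C)=O)cc2)c1` — 18100 nM
compound 2 `NS(=O)(=O)c1ccc(-n2nc(-c3ccccc3)cc2-c2cc(O)ccc2O)cc1` — 86600 nM

Of the compounds shown here, two have been measured in a functional assay on cells (Cancer cell lines, Homo sapiens) for cytotoxicity, read by sulforhodamine B assay, with a stated time of 48 h; a lower number here means a stronger inhibitor of growth, a higher number a weaker inhibitor of growth. Compound 1 `COc1ccc(OC)c(-c2cc(-c3ccccc3)nn2-c2ccc(S(=O)(=O)NC(C)=O)cc2)c1` gives 18100 nM. Compound 2 `NS(=O)(=O)c1ccc(-n2nc(-c3ccccc3)cc2-c2cc(O)ccc2O)cc1` gives 86600 nM, the higher of the two numbers; the gap to compound 1 is beyond the scatter, but the two compounds differ in more than one place, so no single change can be credited with it.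

Compound 3 `CC(=O)NS(=O)(=O)c1ccc(-n2nc(-c3ccccc3)cc2-c2cc(O)ccc2O)cc1` has not been measured. It differs from compound 2 by acetyl in place of hydrogen on a sulfonamide nitrogen. Among the compounds with values here, no pair of measured compounds isolates this change, so there is no reference step for it. Within the data shown here, compound 1, the only compound that already carries the acetyl on its sulfonamide nitrogen, also carries different substituents on its other aryl ring, so its value cannot be read as the effect of the acetyl alone.

With nothing in the series that isolates this change, the expected step in this assay from compound 2 to compound 3 is small, a 1.4-fold lower number from compound 2 to compound 3 (0.16 log units; within the scatter), and may not exceed the scatter. Compound 3 is estimated at 60000 nM, with a range from 20000 nM to 180000 nM.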

Compound 3, concentration for 50% growth inhibition: 90400 nM
Compound 3: middle estimate off by 1.5-fold (0.18 log units), on the low side, within the range that was stated.
By their numbers in this assay, from the lowest: compound 1; then compounds 2 and 3 (each within the scatter of the next).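

In this assay, acetyl in place of hydrogen on a sulfonamide nitrogen, with the 2,5-dihydroxyphenyl group held fixed, gives a 1.0-fold higher number from compound 2 to compound 3 (0.02 log units; within the scatter), so with this aryl group the change cannot be told apart from the scatter. With the acetylsulfamoyl group held fixed, 2,5-dihydroxyphenyl in place of 2,5-dimethoxyphenyl on an aromatic carbon gives a 5.0-fold higher number from compound 1 to compound 3 (0.70 log units; beyond the scatter), which makes this the only single-place step shown that lies beyond the scatter. No measurement is at hand that accounts for the size of either step.

As far as these compounds go, the acetyl step has been read only with 2,5-dihydroxyphenyl on the shared core, so its size with 2,5-dimethoxyphenyl remains open. Also open, from the compounds shown here alone, is whether a different group on the sulfonamide nitrogen, such as a methyl, a propionyl or a benzoyl, would give a step beyond the scatter in this assay.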